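Urea to aryl amide on a shared core

The compounds below may be only part of what the source reports. "The series", "measured", "known", "first", "only" and "open" are said of these compounds alone.

Compound 2 `CCCCNC(=O)Nc1cc2nc(C3CCCCC3)[nH]c2cc1N(C)C` carries a butylamino group on the carbonyl carbon. In an ADME assay on Vero cells (Chlorocebus sabaeus) for cytotoxicity, read by resazurin assay, with a stated time of 3 days (a higher number here means a weaker inhibitor, a lower number a stronger inhibitor), compound 2 gives > 100 ug/mL, which is a limit of the assay and not a number. Compound 1 `CCCCOC(=O)Nc1cc2nc(C3CCCCC3)[nH]c2cc1N(C)C` differs from it only by butoxy in place of butylamino. In this assay compound 1 gives > 100 ug/mL, also a limit. The step that the two limits leave unreadable from compound 1 to compound 2 is therefore unreadable, and the limit of > 100 ug/mL in this assay, at which 2 of the 2 values shown sit, is all the evidence there is. Compound 3 `Cc1ccc(C(=O)Nc2cc3nc(C4CCCCC4)[nH]c3cc2N(C)C)cc1` brings (4-methylphenyl in place of butylamino on a carbonyl carbon). Within the data shown here, no measured step bears on this change. Compound 3 is expected to stay near the limit, with an estimated step of a number no higher from compound 2 to compound 3 (the limit leaves the size open) and an estimated value of 100 ug/mL (range 40 ug/mL to 200 ug/mL).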

Compound 3, half-maximal inhibitory concentration: > 100 ug/mL
Compound 3 ended at the assay's limit; the forecaster's own chance of this, stated with the estimate: 60%; the middle value lies on the limit itself.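

No step can be read among compound 1, compound 2 and compound 3 in this assay, since each value is a limit and not a number: the limit of > 100 ug/mL in this assay, at which 3 of the 3 values shown sit.

The compounds shown leave open whether butoxy, butylamino and 4-methylphenyl differ at all in this assay.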